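The compounds below may be only part of what the source reports. "The series", "measured", "known", "first", "only" and "open" are said of these compounds alone.

Compound 1 `CC(=O)N1CCc2nc(C#Cc3ccccc3)sc2C1`: in an assay on HEK293 cells for positive allosteric modulation of metabotropic glutamate receptor 5 (Homo sapiens), read by FLIPR, with a stated time of 1 h (on this read-out lower numbers stand for an effect already at smaller amounts and higher numbers for an effect only at larger amounts of compound), compound 1 gives only a limit, > 10000 nM.
Compound 2 `COC1CC(C(=O)N2CCc3nc(C#Cc4ccccc4)sc3C2)C1`: in this assay compound 2 gives 640 nM.

Compound 2 thus stands on the only number shown; the other value is the limit of > 10000 nM in this assay, at which 1 of the 2 values shown sits. Compound 3 `O=C(C1CCCO1)N1CCc2nc(C#Cc3ccccc3)sc2C1` differs from compound 2 by oxolan-2-yl in place of 3-methoxycyclobutyl on a carbonyl carbon. Within the data shown here, the one measured step, an at least 15-fold lower number from compound 1 to compound 2 (1.19 log units; beyond the scatter), was large but concerns methyl against a ring, so it bears on this ring-for-ring swap only loosely. Compound 3 is therefore expected to land near compound 2, with no step beyond the scatter. Compound 3 is estimated at 1000 nM, between 300 nM and 4000 nM, which would mean a 1.6-fold higher number from compound 2 to compound 3 (0.19 log units; within the scatter).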

Compound 3, half-maximal effective concentration: 790 nM
Beside the measured number, compound 3's estimate is 1.3-fold (0.10 log units) above it, and the stated range covers the measured number.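

Exchanging one ring on the carbonyl carbon for another changes little here: oxolan-2-yl in place of 3-methoxycyclobutyl gives a 1.2-fold higher number from compound 2 to compound 3 (0.09 log units; within the scatter). Oxolan-2-yl in place of methyl also gives a large step, an at least 12-fold lower number from compound 1 to compound 3 (1.10 log units; beyond the scatter), so two different rings now stand against methyl. That step is only a bound, because compound 1 in this assay gives a limit and not a number: the limit of > 10000 nM in this assay, at which 1 of the 3 values shown sits.

The compounds shown leave open whether an open chain such as n-butyl on the carbonyl carbon would serve as well as these rings. They also leave open how a ring carrying an amine, such as piperidin-4-yl, would read.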